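This account rests on a few compounds, and the source may have more. Where it says the series, first, only, none or still open, it means among the compounds named here.

Compound 1 `COc1cccc(-c2nc3c(c(C)nn3-c3ccccc3)c(-c3ccccc3O)c2C#N)c1` is tested in an ADME assay on BJ cells (Homo sapiens) for cytotoxicity, with a stated time of 72 h (a higher number here means that more compound is needed for the effect, a lower number that less compound is needed), where compound 1 gives > 23000 nM, which is a limit of the assay and not a number. Compound 2 `CCc1ccc(-c2nc3c(c(C)nn3-c3ccccc3)c(-c3ccccc3I)c2C#N)cc1` gives > 20000 nM, also a limit. Compound 3 `CCc1ccc(-c2nc3c(c(C)nn3-c3ccccc3)c(-c3ccccc3Br)c2C#N)cc1` gives > 20000 nM, again a limit. For the measured compounds named here, the only step between measured compounds, a step that the two limits leave unreadable from compound 2 to compound 3, therefore cannot be read. Compound 4 `Cc1nn(-c2ccccc2)c2nc(-c3ccc4c(c3)CCCC4)c(C#N)c(-c3ccccc3O)c12` differs from compound 1 as follows: 1,2,3,4-tetrahydronaphthalen-6-yl in place of 3-methoxyphenyl on an aromatic carbon. Going by the values given here, no measured step touches this change, and every value so far sits at the limit of > 20000 nM in this assay, at which 2 of the 3 values shown sit, or at the limit of > 23000 nM in this assay, at which 1 of the 3 values shown sits, so nothing points in either direction. Compound 4 is therefore expected to give 25000 nM, within 10000 nM to 60000 nM, and the expected step that the limit leaves unreadable from compound 1 to compound 4 is expected to lie within the scatter.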

Compound 4, half-maximal effective concentration: > 20000 nM
Compound 4: a limit, no number (the forecaster's own chance of this, stated with the estimate: 80%); the middle value does not contradict the limit.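

Compound 4 gives > 20000 nM, a limit of the assay and not a number, and with compound 1 also at a limit, the step between them cannot be read. The compounds shown leave open what concentration any of them needs for an effect in this assay.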